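A few compounds are considered here, and "the series" means these few. Any claim that something is new, unique, unknown or untested is made for them only; others in the source may bear on it.

Measured compounds:

Compound 1, `COc1cc(/C=N/C(C#N)=C(/C#N)NC(=O)NS(=O)(=O)c2ccc(C)cc2)cc(OC)c1`, gives 25000 nM in a functional assay on Ehrlich cells (Mus musculus) for cytotoxicity, with a stated time of 48 h; on this read-out higher numbers stand for weaker inhibition of growth and lower numbers for stronger inhibition of growth.
Compound 2, `COc1cccc(/C=N/C(C#N)=C(/C#N)NC(=O)NS(=O)(=O)c2ccc(C)cc2)c1OC`, gives 27000 nM in this assay.
Compound 3, `COc1cc(/C=N/c2c(C#N)nc(=O)[nH]c2NS(=O)(=O)c2ccc(C)cc2)cc(OC)c1`, gives 19000 nM in this assay.

Compound 1 and compound 2 share the same core and differ in a single place: 2,3-dimethoxyphenyl in place of 3,5-dimethoxyphenyl on a carbon with a double bond to nitrogen. The measured result of that change is a 1.1-fold higher number from compound 1 to compound 2 (0.03 log units; within the scatter), so the two compounds cannot be told apart by this read-out.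

Compound 3 is built on a different core; the difference between the two cores is not broken down here. In this assay compound 3 gives a number that sits within the usual scatter of both compound 1 and compound 2, so no order among the three can be claimed.

Compound 4, `COc1cccc(/C=N/c2c(C#N)nc(=O)[nH]c2NS(=O)(=O)c2ccc(C)cc2)c1OC`, has not yet been measured in this assay. It stands to compound 3 as compound 2 stands to compound 1: the change is 2,3-dimethoxyphenyl in place of 3,5-dimethoxyphenyl on a carbon with a double bond to nitrogen, made at the same place as before, so it is the same change carried onto the core of compound 3. Because the step of a 1.1-fold higher number from compound 1 to compound 2 (0.03 log units; within the scatter) stayed within the scatter, the step from compound 3 to compound 4 is expected to be of a similar small size, a 1.1-fold higher number from compound 3 to compound 4 (0.04 log units; within the scatter). On that basis compound 4 is estimated to give about 21000 nM in this assay. The expected range for compound 4 runs from 10000 nM to 42000 nM.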

Compound 4, concentration for 50% growth inhibition: 21000 nM
Compound 4: middle estimate and measured number agree at the digits printed; low and high end bracket the measured number.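

On the core of compound 3, putting 2,3-dimethoxyphenyl in place of 3,5-dimethoxyphenyl gives a 1.1-fold higher number from compound 3 to compound 4 (0.04 log units; within the scatter) in this assay. Set side by side, the same change on the two cores gives steps that cannot be told apart: the same change on two cores in this assay, a 1.1-fold higher number (0.03 log units; within the scatter) from compound 1 to compound 2 and a 1.1-fold higher number (0.04 log units; within the scatter) from compound 3 to compound 4, 1.0-fold (0.01 log units) apart, within the scatter of two such steps. This shows that, in this small set, the change behaves alike on both cores, with neither step large enough to stand out from the ordinary spread of repeated measurements, but it does not show that a real effect of the change carries from one core to the other, since no effect clear of that spread has been seen on either core, and two cores are a thin basis for any rule about the series.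

All the compounds shown carry a dimethoxyphenyl group, so it stays open whether a hydroxyl group, an amine or a carboxylic acid on that ring, or a longer chain such as ethoxy in place of methoxy, would give a step clearly beyond the scatter. From the compounds shown here alone, it also stays open whether a step of that larger size would keep its size when carried from the core of compound 1 to the core of compound 3.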